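This account rests on a few compounds, and the source may have more. Where it says the series, first, only, none or still open, it means among the compounds named here.

Compound 1 `O=C(Nc1cc(-c2ccccn2)n[nH]1)N1CCC(c2ccc(Cl)cc2)CC1` was tested in an ADME assay on cells (Peritoneal macrophage cell, Mus musculus) for cytotoxicity, read by fluorescence and resazurin assay, with a stated time of 3 days; on this read-out lower numbers stand for higher toxicity in this test and higher numbers for lower toxicity in this test. In this assay compound 1 gives only a limit, > 55000 nM. Compound 2 `O=C(Nc1[nH]nc(-c2ccccn2)c1C1CC1)c1c(Cl)cccc1Cl` also gives only a limit in this assay, > 64000 nM. The two values show no measurable toxicity for either compound, and neither can be ranked against the other. Compound 3 `O=C(Nc1cc(-c2ccccn2)n[nH]1)N1CCC(Oc2ccccn2)CC1` has not yet been measured. It differs from compound 1 in one place: (pyridin-2-yl)oxy in place of 4-chlorophenyl on a saturated ring carbon. Among the compounds with values here, no step between measured compounds is available to gauge the size of such a change. Compound 1 stands at the limit of > 55000 nM in this assay, at which 1 of the 2 values shown sits. Compound 2 stands at the limit of > 64000 nM in this assay, at which 1 of the 2 values shown sits. On that basis the step that the limit leaves unreadable from compound 1 to compound 3 is expected to be none beyond the scatter. The expected value for compound 3 is 60000 nM, with a range from 20000 nM to 150000 nM, most likely reported again only as a limit.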

Compound 3, half-maximal cytotoxic concentration: > 64000 nM
Compound 3: only a limit was reported; the forecaster's own chance of this, stated with the estimate: 75%; middle value at least 1.0-fold (0.02 log units) from the limit.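

Compound 1 and compound 3 each give only a limit in this assay, and the step between them cannot be read. The compounds shown leave open whether swapping 4-chlorophenyl for (pyridin-2-yl)oxy changes toxicity at all, and at what concentration any of the three would harm these cells.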